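Acetamido for Methylimidazolyl on the Core of Compound 3

The source may report more compounds than this note shows. Statements on the series, on what has been measured and on what is new or still open speak of the compounds shown alone.

Compound 1 `C[C@H](c1ccc(-c2ccccc2-c2nc(=O)o[nH]2)cc1)N(CC1CC1)c1nc2c(C(=O)O)cccc2o1` was tested in a functional assay on CAL1 cells for inhibition of chemerin-like receptor 1 (Homo sapiens), with a stated time of 45 min (a lower number here means a stronger inhibitor, a higher number a weaker inhibitor), and gave 11 nM. Compound 2 `CCCCN(c1nc2c(C(=O)O)cccc2o1)[C@H](C)c1ccc(-c2cc(Cl)ccc2-c2nc(=O)o[nH]2)cc1` gave 1.2 nM in this assay. Compound 3 `CCCCN(c1nc2c(-c3nccn3C)cccc2o1)[C@H](C)c1ccc(-c2ccccc2-c2nnn[nH]2)cc1` gave 10 nM in this assay. Among these three numbers compound 3 stands second highest. Compound 1 lies nearest to it, and the gap between the two is within the usual scatter, so they cannot be told apart. Compound 2 lies furthest, with a lower number, and that gap is beyond the scatter.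

Compound 4 `CCCCN(c1nc2c(NC(C)=O)cccc2o1)[C@H](C)c1ccc(-c2ccccc2-c2nnn[nH]2)cc1` has not yet been measured. It differs from compound 3 in one place: acetamido in place of 1-methyl-1H-imidazol-2-yl on an aromatic carbon. For the measured compounds named here, no pair of measured compounds isolates this change, so there is no measured step to lean on; the expectation rests on the structural change alone, with compound 3 as the only anchor. Compound 4 is expected to give a somewhat higher number, estimated at 25 nM, with a range from 6 nM to 100 nM. The expected step is a 2.5-fold higher number from compound 3 to compound 4 (0.40 log units; beyond the scatter), a modest loss that may just reach beyond the scatter but could also fall inside it.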

Compound 4, half-maximal inhibitory concentration: 22 nM
Beside the measured number, compound 4's estimate is 1.1-fold (0.06 log units) above it; the range from low to high includes it.
By their numbers in this assay, from the lowest: compound 2; then compounds 3, 1 and 4 (each within the scatter of the next, the first and the last beyond it).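

In this assay, for the compounds shown here, acetamido in place of 1-methyl-1H-imidazol-2-yl on this aromatic carbon gives a 2.2-fold higher number from compound 3 to compound 4 (0.34 log units; beyond the scatter) and is the first change at this position that can be read on its own, with the rest of the structure held constant. The step is modest, so with the rest of compound 3 fixed, an aromatic ring on this carbon is not required for inhibition: a group with no ring and one hydrogen-bond donor replaces a five-membered aromatic ring with none, and the compound stays active. Nothing measured here bears on why the step has this size.

Compounds 1 and 2 carry a carboxylic acid on the same carbon but also differ from compound 3 and compound 4 elsewhere, so the acid cannot be placed in this comparison. Still open, as far as these compounds go, is whether a plain amine, a methoxy group or a longer acyl chain on the nitrogen in place of acetyl would keep the number where it is, and whether this step would be the same size with the other groups seen in compounds 1 and 2.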